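Swapping the Sulfonyl Aryl Group of an Inactive Sulfonamide

This account rests on a few compounds, and the source may have more. Where it says the series, first, only, none or still open, it means among the compounds named here.

Compound 1, `O=S(=O)(Nc1ccc2oc(-c3ccccc3)nc2c1)c1ccc(Cl)c(Cl)c1`, is one of three sulfonamides that share a common core and have been examined in an assay on isolated protein for inhibition of malate dehydrogenase, mitochondrial (Sus scrofa), with stated times of 45 min and 30 min; on this read-out higher numbers stand for weaker inhibition and lower numbers for stronger inhibition. In this assay compound 1 reaches only the limit of > 63000 nM, so no true number is known for it. Its nearest relative, compound 2, `O=S(=O)(Nc1ccc2oc(-c3ccccc3)nc2c1)c1ccc(Cl)c(C(F)(F)F)c1`, likewise reaches only the limit of > 63000 nM. The step that the two limits leave unreadable from compound 1 to compound 2 therefore cannot be read. A third compound, compound 3, `O=S(=O)(Nc1ccc(-c2nc3ccccc3o2)cc1)c1cccc(C(F)(F)F)c1`, in which the sulfonamide is attached differently to the core, also gives only the limit of > 63000 nM. Within the data shown here, the whole set thus rests at the limit of > 63000 nM in this assay, at which 3 of the 3 values shown sit, and no measured step carries any readable size.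

Compound 4, `COc1ccc(S(=O)(=O)Nc2ccc3oc(-c4ccccc4)nc3c2)cc1`, differs from compound 1 in one place: 4-methoxyphenyl in place of 3,4-dichlorophenyl on a sulfonyl sulfur. Among the measured compounds shown here, no measured step bears directly on this change, since every comparison among the three measured compounds is hidden by the assay limit. For the measured compounds named here, the three limits are the only guide, and they point to no step that rises above the scatter. Compound 4 is therefore expected to stay near the limit as well, with an estimated step that the limit leaves unreadable from compound 1 to compound 4. The estimated value for compound 4 in this assay is 90000 nM, between 20000 nM and 400000 nM.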

Compound 4, half-maximal inhibitory concentration: > 63000 nM
Compound 4: no number, only a limit; the forecaster's own chance of this, stated with the estimate: 85%; the middle value does not contradict the limit.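

In this assay compound 4 gives > 63000 nM as a limit and not a number. Compound 1 also gives only a limit, so no step can be read between compound 1 and compound 4, and the set stays flat: the limit of > 63000 nM in this assay, at which 4 of the 4 values shown sit. The compounds shown leave open which sulfonyl aryl group, if any, gives measurable inhibition on the shared core.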